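The source may report more compounds than this note shows. Statements on the series, on what has been measured and on what is new or still open speak of the compounds shown alone.

Measured in an ADME assay on HEK-293T cells (Homo sapiens) for cytotoxicity, read by CCK-8 assay, with a stated time of 48 h; a lower number here means a stronger inhibitor, a higher number a weaker inhibitor:

- compound 1 `O=S(=O)(NCCNC(=S)Nc1cc(C(F)(F)F)cc(C(F)(F)F)c1)c1ccc(-c2ccccc2OCc2cccc(O)c2)s1` gives > 20000 nM
- compound 2 `O=S(=O)(NCCNC(=S)Nc1cc(C(F)(F)F)cc(C(F)(F)F)c1)c1ccc(-c2ccccc2OCc2ccccc2)s1` gives 8500 nM

Compound 1 sits at a limit of the assay, not at a number (the limit of > 20000 nM in this assay, at which 1 of the 2 values shown sits). Among the measured compounds shown here, compound 2 , at 8500 nM, holds the only actual number in this assay so far.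

Next is compound 3 `O=[N+]([O-])c1ccc(Oc2ccccc2-c2ccc(S(=O)(=O)NCCNC(=S)Nc3cc(C(F)(F)F)cc(C(F)(F)F)c3)s2)cc1`, with 4-nitrophenyl in place of benzyl on an oxygen on an aromatic ring. For the measured compounds named here, the only measured step, an at least 2.3-fold lower number from compound 1 to compound 2 (0.37 log units; beyond the scatter), is a different change, hydrogen in place of hydroxy on an aromatic carbon, so it bears on this one only loosely. It suggests that changes in this part of the structure can move the number by a modest amount. No direction can be carried over from it, so a step of modest size at most is expected, either way. The expected step is a 1.1-fold higher number from compound 2 to compound 3 (0.02 log units; within the scatter). For compound 3 the estimated value is 9000 nM, with an expected range of 3500 nM to 20000 nM.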

Compound 3, half-maximal inhibitory concentration: 6000 nM
The estimate for compound 3 lay 1.5-fold (0.18 log units) above the measured number; low and high end bracket the measured number.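

In this assay, 4-nitrophenyl in place of benzyl on the oxygen on an aromatic ring gives a 1.4-fold lower number from compound 2 to compound 3 (0.15 log units; within the scatter), so the two groups are not told apart here, and this position accepts a nitro-bearing aromatic ring without a step beyond the scatter. Against 3-hydroxybenzyl at the same place, the change gives an at least 3.3-fold lower number from compound 1 to compound 3 (0.52 log units; beyond the scatter), so compound 1 now differs beyond the scatter from both compound 2 and compound 3, whose step to each other stays within it. The size of those two steps remains open-ended, as compound 1 stands at a limit and not at a number: the limit of > 20000 nM in this assay, at which 1 of the 3 values shown sits.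

From the compounds shown here alone, whether an amine or a carboxylic acid in place of the nitro group of 4-nitrophenoxy would move the number beyond the scatter remains open. Also open, going by these compounds, is whether the hydroxy group on benzyl would have the same effect on the 4-nitrophenyl ring.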